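Amide for acid on two related scaffolds

A few compounds are considered here, and "the series" means these few. Any claim that something is new, unique, unknown or untested is made for them only; others in the source may bear on it.

The study concerns three measured compounds and one that awaits measurement. Compound 3 `O=C(O)CCc1ccncc1-c1ccc2ccccc2c1` and compound 1 `CNC(=O)CCc1ccncc1-c1ccc2ccccc2c1` share one core, while compound 2 `Cn1ccc2cc(-c3cnccc3/C=C/C(=O)O)ccc21` is built on a second core; the difference between the two cores is not broken down here. In an assay on a protein complex for inhibition of CDK8/Cyclin C (Homo sapiens), with a stated time of 1 h (a lower number here means a stronger inhibitor, a higher number a weaker inhibitor), compound 3 gives 50.5 nM, and compound 1 gives 21.1 nM. The change between them, (methylamino in place of hydroxy on a carbonyl carbon), produced a 2.4-fold lower number from compound 3 to compound 1 (0.38 log units; beyond the scatter). In this assay compound 2 gives 26.8 nM; its value and that of compound 1 lie within the scatter of each other, as do its value and that of compound 3, so no order among them is claimed.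

Compound 4 `CNC(=O)/C=C/c1ccncc1-c1ccc2c(ccn2C)c1` repeats the change on the second core: methylamino in place of hydroxy on a carbonyl carbon. The place differs from the earlier case in its other neighbour, a double-bonded chain carbon here against a saturated chain carbon before, so this is the same kind of change rather than the same change. The expected step from compound 2 to compound 4 in this assay is a 2.1-fold lower number from compound 2 to compound 4 (0.31 log units; beyond the scatter), which rests on the measured move from compound 3 to compound 1, a 2.4-fold lower number from compound 3 to compound 1 (0.38 log units; beyond the scatter). The expectation is tempered in that the surroundings of the place are not identical. Compound 4 is therefore estimated at 13 nM, with an expected range from 6 nM to 30 nM.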

Compound 4, half-maximal inhibitory concentration: 77.6 nM
Estimate against measurement, compound 4: 6.0-fold (0.78 log units) below, and the stated range ends below it.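

On the second core, the same exchange of hydroxy for methylamino on a carbonyl carbon gave the opposite result in this assay, with a 2.9-fold higher number from compound 2 to compound 4 (0.46 log units; beyond the scatter). Set beside the earlier step, this shows that in this series the change does not carry from one core to the other with its direction or its size intact: the same change on two cores in this assay, a 2.4-fold lower number (0.38 log units; beyond the scatter) from compound 3 to compound 1 and a 2.9-fold higher number (0.46 log units; beyond the scatter) from compound 2 to compound 4, 6.9-fold (0.84 log units) apart, beyond the scatter of two such steps. It does not show what sets the two steps apart, as the two pairs differ both in the core and in the other neighbour of the carbonyl carbon, a saturated chain carbon from compound 3 to compound 1 and a double-bonded chain carbon from compound 2 to compound 4, and these four compounds cannot separate those two differences.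

The compounds shown leave open whether the opposite steps follow the core or the chain, a question that a carboxylic acid and its methylamide with a saturated chain on the second core, or with a double-bonded chain on the first, would address. They also leave open whether a plain amino group or a dimethylamino group on the same carbonyl carbon would follow the methylamino group on either core.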